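Two Methyls on the Sulfonyl Aryl Ring

The compounds below may be only part of what the source reports. "The series", "measured", "known", "first", "only" and "open" are said of these compounds alone.

Compound 1 `Cc1ccc(S(=O)(=O)c2cnc3ccc(Cl)cc3c2N2CCC(C)CC2)cc1C` — 84%
Compound 2 `Cc1ccc(S(=O)(=O)c2cnc3ccc(F)cc3c2N2CCC(C)CC2)cc1F` — 86%
Compound 3 `CC1CCN(c2c(S(=O)(=O)c3ccccc3)cnc3ccc(F)cc23)CC1` — 40%

In an assay on isolated protein for displacement of a labelled ligand from metabotropic glutamate receptor 5 (Homo sapiens), with a stated time of 60 min, tested at 1 uM (a higher number here means more inhibition at the concentration tested (going by the name of the read-out), a lower number less inhibition), compound 3 gives 40%, the lowest of the three numbers; compound 1 stands a good deal higher at 84%, and compound 2 higher still at 86%, both beyond the scatter. Compound 4 `Cc1ccc(S(=O)(=O)c2cnc3ccc(F)cc3c2N2CCC(C)CC2)cc1C` has not yet been measured. It differs from compound 3 in one place: 3,4-dimethylphenyl in place of phenyl on a sulfonyl sulfur.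

Among the measured compounds shown here, the one measured step that bears on this is a number 46 percentage points lower from compound 2 to compound 3 (beyond the scatter), where the phenyl lost its 3-fluoro-4-methyl substitution and the read-out fell sharply. Compound 4 goes the other way, restoring two substituents to the phenyl, and compound 1 already shows that a 3,4-dimethylphenyl on a sulfonyl sulfur sits with a high value of 84% on a closely related core. A large upward step is therefore expected for compound 4, about a number 45 percentage points higher from compound 3 to compound 4 (beyond the scatter). The estimate for compound 4 in this assay is 85%, with a range from 72% to 94%.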

Compound 4, a percentage reported as inhibition, at one concentration (the size of the read-out at that concentration, not a potency): 92%
Beside the measured number, compound 4's estimate is 7 percentage points below it; measured number inside the range.
By their numbers in this assay, from the lowest: compound 3; then compounds 1, 2 and 4 (each within the scatter of the next).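

In this assay, the step of a number 52 percentage points higher from compound 3 to compound 4 (beyond the scatter) isolates the change on the sulfonyl sulfur, showing on one shared core that 3,4-dimethylphenyl in place of phenyl accounts for a large gain by itself. The step of a number 6 percentage points higher from compound 2 to compound 4 (within the scatter) shows that methyl and fluoro are not told apart on that aromatic ring, while the step of a number 8 percentage points higher from compound 1 to compound 4 (within the scatter) shows the same for fluoro and chloro on the core, so compound 1, compound 2 and compound 4 form one high group. Nothing available explains why the substituted rings read so far above the plain phenyl.

The compounds shown leave open whether a single methyl on the phenyl would carry the same gain, since each high compound has two substituents there. They also leave open how a methoxy or an amine on that ring would read.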